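Ring amide nitrogen substituent swap in the shared core

A few compounds are considered here, and "the series" means these few. Any claim that something is new, unique, unknown or untested is made for them only; others in the source may bear on it.

Compound 2 `COc1cccc(N2C(=O)COc3ccc(-c4cnc(OC)c(NS(=O)(=O)c5ccc(F)cc5)c4)cc32)c1` stands at the edge of what the assay can report: in a functional assay on HCT-116 cells (Homo sapiens) for antiproliferative activity, read by MTT assay, with a stated time of 72 h (on this read-out higher numbers stand for weaker inhibition and lower numbers for stronger inhibition), compound 2 gives > 40000 nM, which is a limit of the assay and not a number. Compound 1 `COc1cccc(N2C(=O)COc3ccc(-c4cnc(Cl)c(NS(=O)(=O)c5ccc(F)cc5)c4)cc32)c1` is in the same position, since in this assay compound 1 gives > 40000 nM, again a limit. Compound 3 `O=C1COc2ccc(-c3cnc(Cl)c(NS(=O)(=O)c4ccc(F)cc4)c3)cc2N1` in this assay gives > 40000 nM, also a limit. This is summarised by the limit of > 40000 nM in this assay, at which 3 of the 3 values shown sit. As a consequence the step that the two limits leave unreadable from compound 1 to compound 2 and the step that the two limits leave unreadable from compound 1 to compound 3 cannot be read in size or direction.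

Going by the values given here, compound 4 `COc1ncc(-c2ccc3c(c2)N(c2ccc(Cl)cc2)C(=O)CO3)cc1NS(=O)(=O)c1ccc(F)cc1` is the unmeasured member. 4-chlorophenyl in place of 3-methoxyphenyl on an amide-type nitrogen in a ring The only measured step that changes the same ring amide nitrogen is a step that the two limits leave unreadable from compound 1 to compound 3, which is unreadable, so there is no measured guide to how this position responds. Among the compounds with values here, with every value so far sitting at the limit, the step that the limit leaves unreadable from compound 2 to compound 4 is expected to leave compound 4 at or beyond the limit as well. Compound 4 is therefore estimated at 60000 nM, within 15000 nM to 200000 nM, most likely reported only as a limit.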

Compound 4, half-maximal inhibitory concentration: 19200 nM
Estimate against measurement, compound 4: 3.1-fold (0.49 log units) above; the range from low to high includes it.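

Going by these compounds alone, replacing 3-methoxyphenyl with 4-chlorophenyl on the amide-type nitrogen gives an at least 2.0-fold lower number from compound 2 to compound 4 (0.31 log units; beyond the scatter) in this assay, the first readable step, and it shows that a change at this position can bring a compound off the limit. From the compounds shown here alone, the true size of the step remains unknown, since compound 2 has only a limit and the printed figure is a bound. Compound 4 is the only compound here with a number rather than a limit: the limit of > 40000 nM in this assay, at which 3 of the 4 values shown sit.

Going by these compounds, the steps from compound 1 to compound 2 and from compound 1 to compound 3 cannot be read, so it remains open whether the change would also register with chloro in place of methoxy on the aromatic carbon. Also open, on these data alone, is how this nitrogen responds to an unsubstituted phenyl or to a phenyl carrying an amine or a carboxylic acid.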